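Extending the aryl chain on a 5-alkynyl uracil

The source may hold more compounds than are shown below. What is called first, only, known or untested is meant among the compounds shown, and "the series" means these compounds.

Compound 1, `Cc1ccc(C#Cc2cn(C/C=C\CN3C(=O)c4ccccc4C3=O)c(=O)[nH]c2=O)cc1`: 238000 nM
Compound 2, `CCCCCCC#Cc1cn(C/C=C/CN2C(=O)c3ccccc3C2=O)c(=O)[nH]c1=O`: 28000 nM

In a functional assay on CCRF-CEM cells (Homo sapiens) for antiproliferative activity, read by MTT assay, with a stated time of 3 days (a lower number here means a stronger inhibitor, a higher number a weaker inhibitor), compound 1 gives 238000 nM, the higher of the two numbers, and compound 2 gives 28000 nM, a gap that lies beyond the scatter. Compound 3, `CCCCCc1ccc(C#Cc2cn(C/C=C\CN3C(=O)c4ccccc4C3=O)c(=O)[nH]c2=O)cc1`, has not been measured; it differs from compound 1 by butyl in place of hydrogen on a saturated chain carbon bound to an aromatic carbon. Within the data shown here, no step between measured compounds shows what such a change does, so the expectation rests on the trend that the longer chain of compound 2 goes with a lower number. A moderate drop is expected, a 3.0-fold lower number from compound 1 to compound 3 (0.47 log units; beyond the scatter), with compound 3 estimated at 80000 nM, between 20000 nM and 240000 nM.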

Compound 3, half-maximal inhibitory concentration: 102000 nM
The estimate for compound 3 lay 1.3-fold (0.11 log units) below the measured number; the measured number falls inside the stated range.
By their numbers in this assay, from the lowest: compound 2; then compound 3; then compound 1.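

In this assay, pentyl in place of methyl on the phenyl ring gives a 2.3-fold lower number from compound 1 to compound 3 (0.37 log units; beyond the scatter) as a modest change. Among these compounds, this is the first direct reading of this position, and it shows that extending the chain there lowers the number, although compound 3 still gives 102000 nM and remains a weak inhibitor. Nothing measured here accounts for this change.

As far as these compounds go, whether intermediate chains such as ethyl or propyl, or a longer chain such as octyl, would lower the number further remains open. So does the effect of an amine or a carboxylic acid at the chain's end.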